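Nitro in place of trifluoromethyl: a cytotoxicity estimate

The compounds below may be only part of what the source reports. "The series", "measured", "known", "first", "only" and "open" are said of these compounds alone.

Measured in an ADME assay on Vero cells (Chlorocebus sabaeus) for cytotoxicity, read by resazurin assay, with a stated time of 72 h; a lower number here means a stronger inhibitor, a higher number a weaker inhibitor:
- compound 1 `COc1ccc(C(=O)CCN2CCN(c3ccc([N+](=O)[O-])cc3)CC2)cc1`: 587000 nM
- compound 2 `O=C(CCN1CCN(c2ccc(F)cc2)CC1)c1ccc(F)c(F)c1`: 385000 nM
- compound 3 `O=C(CCN1CCN(c2ccc(C(F)(F)F)cc2)CC1)c1ccc(F)c(F)c1`: 14000 nM

Compound 3 has the lowest number of the three, with both gaps beyond the scatter. The next structure, compound 4 `O=C(CCN1CCN(c2ccc([N+](=O)[O-])cc2)CC1)c1ccc(F)c(F)c1`, has nitro in place of trifluoromethyl on an aromatic carbon.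

Among the measured compounds shown here, only one measured step bears directly on this place: a 28-fold lower number from compound 2 to compound 3 (1.44 log units; beyond the scatter). This step is large and shows that a change here can move the number in this assay well beyond the scatter. It involves fluoro, however, not nitro. Nitro also occurs in compound 1 at 587000 nM, but that compound differs from compound 4 in another place as well, so it offers only loose guidance.

Trifluoromethyl is the group that sets compound 3 apart from compound 2, and it leaves here, so a higher number is expected. The expected change is a 6.4-fold higher number from compound 3 to compound 4 (0.81 log units; beyond the scatter). For compound 4 the estimated value is 90000 nM, with an expected range of 18000 nM to 450000 nM.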

Compound 4, half-maximal inhibitory concentration: 122000 nM
For compound 4 the middle estimate is 1.4-fold (0.13 log units) below the measured one, within the range that was stated.
By their numbers in this assay, from the lowest: compound 3; then compound 4; then compounds 2 and 1 (each within the scatter of the next).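

In this assay, an 8.7-fold higher number from compound 3 to compound 4 (0.94 log units; beyond the scatter) and a 3.2-fold lower number from compound 2 to compound 4 (0.50 log units; beyond the scatter) place nitro in the middle of the three groups compared on this aromatic carbon, with trifluoromethyl giving the lowest number and fluoro the highest. The effect at this place is therefore graded rather than a simple contrast between trifluoromethyl and everything else, at least for these three groups on the shared core. With nitro held constant, 3,4-difluorophenyl in place of 4-methoxyphenyl gives a 4.8-fold lower number from compound 1 to compound 4 (0.68 log units; beyond the scatter) and shows that the number also responds to the group on the carbonyl carbon.

Open, going by these compounds, is where an amine, a nitrile or a carboxylic acid on this aromatic carbon would fall relative to these three groups, and whether their order carries over with 4-methoxyphenyl on the carbonyl carbon. Nothing among the data shown accounts for the order of the three groups.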